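Shifting a nitro group on a shared core

A few compounds are considered here, and "the series" means these few. Any claim that something is new, unique, unknown or untested is made for them only; others in the source may bear on it.

Compound 1, `C=C(C(=O)c1ccc(OC)cc1)C(OC(=O)c1ccccc1)C(CC)CC`, gives 17900 nM in a functional assay on MCF7 cells (Homo sapiens) for inhibition, read by XTT assay, with a stated time of 48 h; a higher number here means a weaker inhibitor, a lower number a stronger inhibitor.
Compound 2, `C=C(C(=O)c1ccc(OC)cc1)C(OC(=O)c1ccccc1)C1CCCCC1`, gives 34300 nM in this assay.
Compound 3, `C=C(C(=O)c1ccc(OC)cc1)C(OC(=O)c1ccccc1)c1ccc([N+](=O)[O-])cc1`, gives 56100 nM in this assay.

Compound 3 has the highest number of the three: the step of a 3.1-fold higher number from compound 1 to compound 3 (0.50 log units; beyond the scatter) lies beyond the scatter, whereas a 1.6-fold higher number from compound 2 to compound 3 (0.21 log units; within the scatter) does not. Compound 4, `C=C(C(=O)c1ccc(OC)cc1)C(OC(=O)c1ccccc1)c1ccccc1[N+](=O)[O-]`, holds the same atoms joined differently: 2-nitrophenyl in place of 4-nitrophenyl on a saturated chain carbon bound to a double-bonded chain carbon and an oxygen next to a carbonyl group. Going by the values given here, no measured step moves a substituent around a ring; the steps of a 1.9-fold higher number from compound 1 to compound 2 (0.28 log units; within the scatter), a 3.1-fold higher number from compound 1 to compound 3 (0.50 log units; beyond the scatter) and a 1.6-fold higher number from compound 2 to compound 3 (0.21 log units; within the scatter) each exchange the whole group at that place, and only one of them exceeds the scatter. Within these compounds they show only that 4-nitrophenyl gives a higher number than either alkyl group, and nothing about where the nitro group stands. The expected step of a 1.1-fold lower number from compound 3 to compound 4 (0.05 log units; within the scatter) is accordingly none beyond the scatter. Compound 4 is estimated at 50000 nM in this assay, with a range from 20000 nM to 125000 nM.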

Compound 4, half-maximal inhibitory concentration: 11800 nM
For compound 4 the middle estimate is 4.2-fold (0.63 log units) above the measured one; the whole stated range lies above it.
By their numbers in this assay, from the lowest: compounds 4, 1, 2 and 3 (each within the scatter of the next, the first and the last beyond it).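

Where the nitro group stands matters at this place in this assay: 2-nitrophenyl in place of 4-nitrophenyl gives a 4.8-fold lower number from compound 3 to compound 4 (0.68 log units; beyond the scatter), the first measured step that keeps the nitrophenyl group and changes only its attachment. A nitrophenyl group as such therefore does not set the number: 2-nitrophenyl in place of cyclohexyl gives a 2.9-fold lower number from compound 2 to compound 4 (0.46 log units; beyond the scatter), while in place of pentan-3-yl it gives a 1.5-fold lower number from compound 1 to compound 4 (0.18 log units; within the scatter). Nothing measured here explains the difference between the two nitrophenyl groups.

The compounds shown leave open how 3-nitrophenyl would compare. They also leave open whether the nitro group of 2-nitrophenyl could give way to an amine or a methoxy group with the same result.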